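Selenium carbamates: cytotoxicity in a leukaemia cell line

The source may hold more compounds than are shown below. What is called first, only, known or untested is meant among the compounds shown, and "the series" means these compounds.

Measured compounds
- compound 1, `CC(C)COC(=O)Nc1ccc([Se][Se]c2ccc(NC(=O)OCC(C)C)cc2)cc1`: 70200 nM
- compound 2, `C=CCOC(=O)Nc1ccc([Se]C#N)cc1`: 68600 nM
- compound 3, `CCCCOC(=O)Nc1ccc([Se][Se]c2ccc(NC(=O)OCCCC)cc2)cc1`: 72300 nM

All three compounds were tested in a functional assay on CCRF-CEM cells (Homo sapiens) for cytotoxicity, read by MTT assay, with a stated time of 72 h; on this read-out higher numbers stand for lower toxicity in this test and lower numbers for higher toxicity in this test. In this assay compound 1 gives 70200 nM, compound 3 gives 72300 nM, and compound 2 gives 68600 nM. The three numbers cannot be told apart: the value of compound 2 is separated from that of compound 1 and from that of compound 3 by gaps that fall within the usual scatter of repeated measurements, so compound 2 stands level with both diselenides rather than apart from them.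

The next compound, compound 4, `CC(C)COC(=O)Nc1ccc([Se]C#N)cc1`, keeps the selenocyanate and the aryl carbamate of compound 2 and alters only the ester chain. The change is isopropyl in place of vinyl on a saturated chain carbon bound to an oxygen next to a carbonyl group. Read one bond further out, it is allyl to isobutyl, or allyloxy to isobutoxy.

Within the data shown here, no step between measured compounds tests this change directly. What is known is that the isobutyl carbamate of compound 1 and the butyl carbamate of compound 3 give numbers indistinguishable from compound 2, so the chain on the carbamate oxygen has so far left this read-out unmoved. The expected step from compound 2 to compound 4 is therefore none beyond the scatter, a 1.0-fold higher number from compound 2 to compound 4 (0.00 log units; within the scatter). Compound 4 is estimated at 69000 nM, with a range from 35000 nM to 140000 nM.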

Compound 4, concentration lethal to 50% of the cells: 68700 nM
Compound 4: middle estimate off by 1.0-fold (0.00 log units), on the high side; the measured number falls inside the stated range.
By their numbers in this assay, from the lowest: compounds 2, 4, 1 and 3 (each within the scatter of the next).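

In this assay, among these compounds, isopropyl in place of vinyl on a saturated chain carbon bound to an oxygen next to a carbonyl group gives a 1.0-fold higher number from compound 2 to compound 4 (0.00 log units; within the scatter), the first direct reading of this chain swap with the selenocyanate held constant. Until now, the isobutyl and butyl carbamates had been seen only as diselenides and the allyl carbamate only as a selenocyanate, so the chain and the selenium group could not be read apart; within the selenocyanates, allyl and isobutyl now stand level on this read-out. Nothing measured alongside these numbers speaks to what lies behind this result.

All four compounds shown stand level, so it remains open whether any group on the carbamate oxygen can move this read-out at all; a longer chain such as octyl, or a chain ending in an amine or a carboxylic acid, would probe that. The selenium-bearing end also remains open, since a thiocyanate in place of the selenocyanate lies outside the compounds shown.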